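Exchanging the side chain of compound 2

The source may hold more compounds than are shown below. What is called first, only, known or untested is meant among the compounds shown, and "the series" means these compounds.

For the measured compounds named here, in a functional assay on MCF7 cells (Homo sapiens) for inhibition, read by fluorescence, with a stated time of 72 h (a higher number here means a weaker inhibitor, a lower number a stronger inhibitor), compound 2 `CC(C)[C@H](N)COc1nc(NC(=N)N)c2ncn(C(C)C)c2n1` gives 3400 nM as the only true number so far. Compound 1 `CC[C@@H](N)COc1nc(NC(=N)N)c2ncn(C(C)C)c2n1` shows > 100000 nM which is a limit of the assay and not a number. Going by the values given here, the one measured step is an at least 29-fold lower number from compound 1 to compound 2 (1.46 log units; beyond the scatter) and it is large and beyond the scatter, so a small change in the chain on the oxygen already moved the result strongly. In compound 3 `CC(C)n1cnc2c(NC(=N)N)nc(N3CCC[C@@H]3CO)nc21` the side chain is exchanged, as 2-(hydroxymethyl)pyrrolidin-1-yl in place of 2-amino-3-methylbutoxy on an aromatic carbon sets out, with 2-(hydroxymethyl)pyrrolidin-1-yl in place of 2-amino-3-methylbutoxy on an aromatic carbon between two ring nitrogen atoms. Among the compounds with values here, no measured step covers this exchange. The large step of an at least 29-fold lower number from compound 1 to compound 2 (1.46 log units; beyond the scatter) shows how easily the number can be lost, so a moderate rise in this assay toward weaker inhibition is expected, with wide uncertainty. The expected size is a 2.1-fold higher number from compound 2 to compound 3 (0.31 log units; beyond the scatter) as an estimate. The estimated value for compound 3 is 7000 nM with an expected range from 1500 nM to 35000 nM in this estimate.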

Compound 3, half-maximal inhibitory concentration: 20400 nM
Estimate against measurement, compound 3: 2.9-fold (0.46 log units) below, within the range that was stated.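

In this assay, putting 2-(hydroxymethyl)pyrrolidin-1-yl in place of 2-amino-3-methylbutoxy on the aromatic carbon between two ring nitrogen atoms gives a 6.0-fold higher number from compound 2 to compound 3 (0.78 log units; beyond the scatter), so a side chain with a five-membered ring at this position keeps measurable inhibition, though weaker. Against the 2-aminobutoxy chain, the same group gives an at least 4.9-fold lower number from compound 1 to compound 3 (0.69 log units; beyond the scatter). That step gives only a bound, since the entry for compound 1 is a limit of the assay and not a number: the limit of > 100000 nM in this assay, at which 1 of the 3 values shown sits.

The exchange changes the oxygen link, the amine and the ring together, so the compounds shown do not separate their contributions. As far as these compounds go, it remains open whether 2-(aminomethyl)pyrrolidin-1-yl, with an amine in place of the hydroxyl on the same ring, would recover the number of compound 2.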